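The compounds below may be only part of what the source reports. "The series", "measured", "known", "first", "only" and "open" are said of these compounds alone.

Of the compounds shown here, three built on one shared core have been measured in a functional assay on A549 cells (Homo sapiens) for inhibition, with a stated time of 72 h; on this read-out lower numbers stand for stronger inhibition and higher numbers for weaker inhibition. Compound 1 `CC1(c2ccccc2)CC(=O)C(C(CC(=O)c2ccc(-c3ccc(Br)cc3)cc2)c2ccccc2)=C(O)O1` gives 9180 nM. Compound 2 `CC1(c2ccccc2)CC(=O)C(C2CC(c3ccc(-c4ccc(Br)cc4)cc3)Cc3ccccc32)=C(O)O1` has the open chain of compound 1 closed into a ring. In this assay compound 2 gives 1830 nM. Compound 3 `CC1(c2ccccc2)CC(=O)C(C2CC(c3ccc(OCc4ccc(C(F)(F)F)cc4)cc3)Cc3ccccc32)=C(O)O1` reaches only a limit of the assay, > 10000 nM in this assay, so for compound 3 a limit and not a number is known. The step of an at least 5.4-fold higher number from compound 2 to compound 3 (0.73 log units; beyond the scatter) therefore has only a lower bound, because compound 3 sits at the limit of > 10000 nM in this assay, at which 1 of the 3 values shown sits.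

Compound 4 `COc1ccc(C2Cc3ccccc3C(C3=C(O)OC(C)(c4ccccc4)CC3=O)C2)cc1` is not yet measured. It differs from compound 3 in one place: hydrogen in place of 4-(trifluoromethyl)phenyl on a saturated chain carbon bound to an oxygen on an aromatic ring. Going by the values given here, no measured pair shows what a methoxy does on this aromatic carbon. Among the compounds with values here, the only nearby comparison is the step of an at least 5.4-fold higher number from compound 2 to compound 3 (0.73 log units; beyond the scatter), which shows that the ether-bearing compound 3 inhibits more weakly than compound 2 by at least a modest amount. Removing the 4-(trifluoromethyl)phenyl undoes part of that change, but methoxy is not 4-bromophenyl, so only a partial recovery is expected, with wide uncertainty. Compound 4 is expected to give about 8000 nM in this assay. For compound 4 the lower end of the estimate is 2000 nM. For compound 4 the upper end of the estimate is 30000 nM. The expected step is an at least 1.2-fold lower number from compound 3 to compound 4 (0.09 log units; that floor lies within the scatter).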

Compound 4, half-maximal inhibitory concentration: > 10000 nM
Compound 4: a limit, no number (the forecaster's own chance of this, stated with the estimate: 40%); middle value at least 1.2-fold (0.09 log units) from the limit.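

In this assay compound 4 reaches a limit of the assay, > 10000 nM, so a limit and not a number is known for it. With methoxy in place of 4-bromophenyl on an aromatic carbon, the result is an at least 5.4-fold higher number from compound 2 to compound 4 (0.73 log units; beyond the scatter), which shows that removing the 4-(trifluoromethyl)phenyl from the ether of compound 3 is not enough to bring a readable value back, and that the loss seen at this position does not need that large group to be present. The step between compound 3 and compound 4 itself cannot be read, because both compounds sit at the same assay limit and any real difference between them is hidden: the limit of > 10000 nM in this assay, at which 2 of the 4 values shown sit.

The compounds shown leave open how far above the limit compound 3 and compound 4 truly lie, and whether any ether on this aromatic carbon can give a measurable value. They also leave open how a plain phenyl without the bromine, a single bromine atom or an amine on this carbon would compare with the 4-bromophenyl of compound 2.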